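Swapping the amide aryl group in a bisindole nitrile series

This account rests on a few compounds, and the source may have more. Where it says the series, first, only, none or still open, it means among the compounds named here.

Measured so far:
compound 1 `CCc1ccc(C(=O)NC[C@H]2c3[nH]c4ccccc4c3C[C@H]3[C@H]4c5[nH]c6ccccc6c5C[C@@H]([C@H](C#N)N23)N4C)cc1` — 170 nM
compound 2 `CN1[C@@H]2c3[nH]c4ccccc4c3C[C@H]1[C@H](C#N)N1[C@@H](CNC(=O)c3ccc4ccccc4c3)c3[nH]c4ccccc4c3C[C@@H]21` — 4650 nM
compound 3 `CN1[C@@H]2c3[nH]c4ccccc4c3C[C@H]1[C@H](C#N)N1[C@@H](CNC(=O)/C=C/c3ccccc3)c3[nH]c4ccccc4c3C[C@@H]21` — 7190 nM

All three share one core and differ only in the group on the amide carbonyl carbon. In a functional assay on MCF7 cells (Homo sapiens) for cytotoxicity, read by MTT assay, with a stated time of 72 h (a lower number here means a stronger inhibitor, a higher number a weaker inhibitor), compound 1 gives the lowest of the three numbers; compound 2 is nearest, and compound 3 is furthest. Both measured steps away from compound 1 are large and beyond the scatter: a 27-fold higher number from compound 1 to compound 2 (1.44 log units; beyond the scatter) and a 42-fold higher number from compound 1 to compound 3 (1.63 log units; beyond the scatter). Between the two larger groups the difference is small: a 1.5-fold higher number from compound 2 to compound 3 (0.19 log units; within the scatter).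

Compound 4 `COc1ccc(/C=C/C(=O)NC[C@H]2c3[nH]c4ccccc4c3C[C@H]3[C@H]4c5[nH]c6ccccc6c5C[C@@H]([C@H](C#N)N23)N4C)cc1` has not yet been measured in this assay. Against compound 1 the change is 2-(4-methoxyphenyl)ethenyl in place of 4-ethylphenyl on a carbonyl carbon. The step that bears on it most directly is a 42-fold higher number from compound 1 to compound 3 (1.63 log units; beyond the scatter), since compound 3 already carries the 2-phenylethenyl group on the carbonyl carbon and compound 4 adds only a methoxy group to that ring. The step to compound 2 points the same way. Compound 4 is therefore expected to lie well above compound 1, close to compound 3, with an expected step of a 35-fold higher number from compound 1 to compound 4 (1.55 log units; beyond the scatter). The estimate for compound 4 in this assay is 6000 nM, with a range from 2000 nM to 18000 nM.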

Compound 4, half-maximal inhibitory concentration: 4220 nM
For compound 4 the middle estimate is 1.4-fold (0.15 log units) above the measured one; the measured number falls inside the stated range.
By their numbers in this assay, from the lowest: compound 1; then compounds 4, 2 and 3 (each within the scatter of the next).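

In this assay, among the compounds shown here, adding a methoxy group to the ring of the 2-phenylethenyl group gives the first reading of a change on that ring, and the result stays within the scatter (a 1.7-fold lower number from compound 3 to compound 4 (0.23 log units; within the scatter)). The comparison with the naphthalen-2-yl group is also within the scatter (a 1.1-fold lower number from compound 2 to compound 4 (0.04 log units; within the scatter)), while the step from the 4-ethylphenyl group remains large (a 25-fold higher number from compound 1 to compound 4 (1.39 log units; beyond the scatter)), so among the four groups on the carbonyl carbon, compound 1 stands apart and compounds 2, 3 and 4 are not separated from one another. No measurement shown explains this gap or the absence of a clear shift with the methoxy group.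

The compounds shown leave open how narrow this preference is: a 4-methylphenyl, 4-propylphenyl or 4-methoxyphenyl group placed directly on the carbonyl carbon would help show whether the ethyl group or the direct attachment of a single phenyl ring goes with the lower number. They also leave open how an amine or a carboxylic acid on that ring would read in this assay, and whether the nitrile on the shared core matters to this result.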